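Pyridyl for fluorophenyl on the ether oxygen

This account rests on a few compounds, and the source may have more. Where it says the series, first, only, none or still open, it means among the compounds named here.

Compound 1 `C=CC(=O)NCc1coc(-c2c(N)ncnc2Nc2ccc(Oc3cccc(F)c3)c(Cl)c2)n1` and compound 2 `C=CC(=O)NCc1coc(-c2c(N)ncnc2Nc2ccc(Oc3ccc(F)cc3)c(Cl)c2)n1` share the same core and differ only in the ring carried on the ether oxygen. In an in vitro ADME assay on microsomes from liver (Mus musculus) for metabolic stability, tested at 5 uM (a lower number here means that the compound disappears faster, a higher number that the compound lasts longer), compound 1 gives > 1.66 h, which is a limit of the assay and not a number. In this assay compound 2 likewise gives > 1.66 h, again a limit. The step that the two limits leave unreadable from compound 1 to compound 2 is therefore unreadable in size and direction; all that the two measurements show is the limit of > 1.66 h in this assay, at which 2 of the 2 values shown sit. Compound 2 thus stands at the edge of what the assay reports, with no number read below it.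

Compound 3 `C=CC(=O)NCc1coc(-c2c(N)ncnc2Nc2ccc(Oc3ccccn3)c(Cl)c2)n1` carries pyridin-2-yl in place of 4-fluorophenyl on an oxygen on an aromatic ring. Within the data shown here, no measured step bears on this exchange: the only step is unreadable, so it gives neither a size nor a direction to carry over. Compound 3 is expected to remain near the limit, with a fair chance that the assay again reports only a limit, and the step of an at least 1.1-fold lower number from compound 2 to compound 3 (0.04 log units; that floor lies within the scatter) is estimated to stay within scatter. The estimate for compound 3 is 1.5 h, with a range from 0.5 h to 3.5 h.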

Compound 3, half-life: 0.25 h
Estimate against measurement, compound 3: 6.0-fold (0.78 log units) above; measured number below the stated range.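

In this assay, among these compounds, the exchange on the oxygen on an aromatic ring gives the first readable step at this position: pyridin-2-yl in place of 4-fluorophenyl gives an at least 6.6-fold lower number from compound 2 to compound 3 (0.82 log units; beyond the scatter). Measured against the other fluorophenyl partner, pyridin-2-yl in place of 3-fluorophenyl gives an at least 6.6-fold lower number from compound 1 to compound 3 (0.82 log units; beyond the scatter), so the same exchange reads beyond the scatter from both fluorophenyl compounds. Both sizes are floors and not measured gaps, as the fluorophenyl side of each step is a limit of the assay and not a number: the limit of > 1.66 h in this assay, at which 2 of the 3 values shown sit.

As far as these compounds go, the step between compound 1 and compound 2 cannot be read, so any effect of where the fluorine sits on the phenyl ring stays open while both values rest at the limit. Compound 3 differs from both fluorophenyl compounds by a ring nitrogen and by the absence of fluorine at once, so the shown compounds cannot separate the two changes; unsubstituted phenyl, pyridin-3-yl or 5-fluoropyridin-2-yl on the same oxygen would bear on that question.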